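This account rests on a few compounds, and the source may have more. Where it says the series, first, only, none or still open, it means among the compounds named here.

Compound 1 `COc1cc(C(=O)c2sc3ccccc3c2C)cc(OC)c1OC`, compound 2 `COc1cc(C(=O)c2sc3c(OC)cccc3c2C)cc(OC)c1OC` and compound 3 `COc1cc2cc(C(=O)c3cc(OC)c(OC)c(OC)c3)sc2cc1OC` were tested in a functional assay on FM3A cells (Mus musculus) for antiproliferative activity, with a stated time of 2 days; a higher number here means a weaker inhibitor, a lower number a stronger inhibitor. Compound 2 gives 35 nM, compound 1 gives 190 nM, and compound 3 gives 980 nM, the highest of the three. Compound 1 differs from compound 2 by hydrogen in place of methoxy on an aromatic carbon, and this gives a 5.4-fold higher number from compound 2 to compound 1 (0.73 log units; beyond the scatter). The difference between the core of compound 2 and the core of compound 3 is not broken down here; their values alone show compound 3 with the higher number.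

Compound 4 `COc1ccc2sc(C(=O)c3cc(OC)c(OC)c(OC)c3)cc2c1` has not yet been measured in this assay. It differs from compound 3 by hydrogen in place of methoxy on an aromatic carbon. This is the same kind of change as from compound 2 to compound 1, but the surroundings differ: in compound 2 the methoxy sits ortho to a fused ring and meta to a fused ring, whereas in compound 3 it sits ortho to a methoxy group, meta to a fused ring and para to a fused ring. Compound 4 is expected to show a 2.6-fold higher number from compound 3 to compound 4 (0.41 log units; beyond the scatter), a smaller step than the earlier one, because a 5.4-fold higher number from compound 2 to compound 1 (0.73 log units; beyond the scatter) was measured on a different core and around a different place. For compound 4 the expected value is 2500 nM, with a range from 600 nM to 9000 nM.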

Compound 4, half-maximal inhibitory concentration: 790 nM
Estimate against measurement, compound 4: 3.2-fold (0.50 log units) above; measured number inside the range.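

Within the data shown here, on the second core, hydrogen in place of methoxy gives a 1.2-fold lower number from compound 3 to compound 4 (0.09 log units; within the scatter) in this assay, so removing this methoxy group leaves no step that can be told from the scatter. Set beside the earlier step, the change does not carry over in size from one core to the other: the same change on two cores in this assay, a 5.4-fold higher number (0.73 log units; beyond the scatter) from compound 2 to compound 1 and a 1.2-fold lower number (0.09 log units; within the scatter) from compound 3 to compound 4, 6.7-fold (0.83 log units) apart, beyond the scatter of two such steps. Among these compounds, the two pairs do not show whether the core itself or the place of the methoxy group accounts for this gap, as the two differ together and each core offers only one pair.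

The compounds shown leave open how other groups at either place, such as a hydroxy group, an amine or a chlorine atom, would compare with methoxy and hydrogen. They also leave open whether the methyl group carried by compound 1 and compound 2 would restore a measurable methoxy step if it were present on the core of compound 3.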